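This account rests on a few compounds, and the source may have more. Where it says the series, first, only, none or still open, it means among the compounds named here.

Compound 1 `COC(=O)/C=C/c1cccc(N(Cc2ccc(/C=C/c3cccc(F)c3)cc2)C(=O)C2CCCCC2)c1` gives 86 nM in an assay on isolated protein with Bile acid receptor (Homo sapiens) as the target; a higher number here means that more compound is needed for the effect, a lower number that less compound is needed. For compound 2 `COC(=O)/C=C/c1cccc(N(Cc2ccc(C(C)(C)C)cc2)C(=O)C2CCCCC2)c1` the assay reports only a limit, > 1000 nM. Among the compounds with values here, the one measured step is therefore an at least 11-fold higher number from compound 1 to compound 2 (1.06 log units; beyond the scatter), and it rests on (the limit of > 1000 nM in this assay, at which 1 of the 2 values shown sits). Compound 3 `COC(=O)/C=C/c1cccc(N(Cc2ccc(-c3cccc(C(C)=O)c3)cc2)C(=O)C2CCCCC2)c1` differs from compound 2 by 3-acetylphenyl in place of tert-butyl on an aromatic carbon, so an aromatic ring stands again where compound 1 also carries one. Because an at least 11-fold higher number from compound 1 to compound 2 (1.06 log units; beyond the scatter) was large, a large step in this assay toward a lower number is expected. Compound 3 is estimated at 150 nM, with a range from 40 nM to 900 nM. This expectation corresponds to an at least 6.6-fold lower number from compound 2 to compound 3 (0.82 log units; beyond the scatter).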

Compound 3, half-maximal effective concentration: 227 nM
Beside the measured number, compound 3's estimate is 1.5-fold (0.18 log units) below it, within the range that was stated.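

With 3-acetylphenyl on this aromatic carbon, the change gives an at least 4.4-fold lower number from compound 2 to compound 3 (0.64 log units; beyond the scatter), so a ring here brings the number back without the ethenyl link of compound 1. That step is only a bound, and its size depends on a limit: the limit of > 1000 nM in this assay, at which 1 of the 3 values shown sits. The ring alone does not fully match the 2-(3-fluorophenyl)ethenyl group, as the change shows a 2.6-fold higher number from compound 1 to compound 3 (0.42 log units; beyond the scatter). Whether the missing ethenyl link or the different ring substituent accounts for this remains open. Going by these compounds, how an amine or a carboxylic acid in place of the acetyl would read is also open.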